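A few compounds are considered here, and "the series" means these few. Any claim that something is new, unique, unknown or untested is made for them only; others in the source may bear on it.

Compound 1 `FC(F)(F)c1ccc(CSc2nc(Nc3ccccc3C(F)(F)F)c3ccccc3n2)cc1` gives > 50000 nM in a functional assay on MDA-MB-231 cells (Homo sapiens) for cytotoxicity, read by MTT assay, with a stated time of 72 h (on this read-out higher numbers stand for weaker inhibition and lower numbers for stronger inhibition), which is a limit of that assay rather than a number.
Compound 2 `FC(F)(F)c1ccc(CSc2nc(Nc3cccc(Cl)c3)c3ccccc3n2)cc1` gives 18000 nM in this assay.
Compound 3 `FC(F)(F)c1ccc(CSc2nc(Nc3cccc(Br)c3)c3ccccc3n2)cc1` gives 22100 nM in this assay.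

Compound 1 thus stands only at the limit of > 50000 nM in this assay, at which 1 of the 3 values shown sits, and both an at least 2.7-fold lower number from compound 1 to compound 2 (0.44 log units; beyond the scatter) and an at least 2.2-fold lower number from compound 1 to compound 3 (0.35 log units; beyond the scatter) read as steps beyond the scatter from that limit, while a 1.2-fold higher number from compound 2 to compound 3 (0.09 log units; within the scatter) stays within it. Compound 4 `CCOc1ccc(Nc2nc(SCc3ccc(C(F)(F)F)cc3)nc3ccccc23)cc1` differs from compound 1 by 4-ethoxyphenyl in place of 2-(trifluoromethyl)phenyl on a nitrogen on an aromatic ring. Within the data shown here, no measured step swaps in a 4-ethoxyphenyl, so the two halogen steps only suggest that leaving the 2-(trifluoromethyl)phenyl can lower the number in this assay. Compound 4 is therefore expected to give 25000 nM, between 8000 nM and 80000 nM. For compound 4 this means an expected step of an at least 2.0-fold lower number from compound 1 to compound 4 (0.30 log units; that floor lies within the scatter), modest at best.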

Compound 4, half-maximal inhibitory concentration: 23000 nM
Beside the measured number, compound 4's estimate is 1.1-fold (0.04 log units) above it; the measured number falls inside the stated range.
By their numbers in this assay, from the lowest: compounds 2, 3 and 4 (each within the scatter of the next). At a limit, above all of these: compound 1.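

The fall in the number on leaving the 2-(trifluoromethyl)phenyl is not confined to the halogen-bearing groups, since it also appears with the 4-ethoxyphenyl on this nitrogen: an at least 2.1-fold lower number from compound 1 to compound 4 (0.33 log units; beyond the scatter). Compound 1 remains only a limit in this assay: the limit of > 50000 nM in this assay, at which 1 of the 4 values shown sits. On the same nitrogen, the 4-ethoxyphenyl cannot be told apart from either halogen-bearing group, with a 1.0-fold higher number from compound 3 to compound 4 (0.02 log units; within the scatter) and a 1.3-fold higher number from compound 2 to compound 4 (0.11 log units; within the scatter).

The compounds shown leave open whether a 3-ethoxyphenyl would read the same as the 4-ethoxyphenyl. They also leave open whether an amine or a carboxylic acid on this phenyl would bring the number lower.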